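The source may hold more compounds than are shown below. What is called first, only, known or untested is meant among the compounds shown, and "the series" means these compounds.

In an ADME assay on the whole organism for pharmacokinetics, with Rattus norvegicus as the target, at a dose of 2 mg/kg by the intravenous route (on this read-out lower numbers stand for slow clearance and higher numbers for fast clearance), compound 1 (`O=c1[nH]c2ncc(-c3ccc(-c4nc[nH]n4)cc3)nc2n1CCC1CCOCC1`) gives 32 mL/min/kg and compound 2 (`CC(C)(O)c1ccc(-c2cnc3c(n2)N(CCC2CCOCC2)C(=O)CN3)cn1`) gives 9 mL/min/kg, the lower of the two numbers and apart from compound 1 by more than the usual scatter. For compound 3 (`CO[C@H]1CC[C@@H](N2CC(=O)Nc3ncc(-c4ccc(C(C)(C)O)nc4)nc32)CC1`) the entry reads "not determined" (no result reported), so it offers no number. Compound 4 (`CO[C@H]1CC[C@H](N2C(=O)CNc3ncc(-c4ccc(C(C)(C)O)nc4)nc32)CC1`) has the same atoms as compound 2, joined differently: 4-methoxycyclohexyl in place of 2-(oxan-4-yl)ethyl on an amide-type nitrogen in a ring, with 4-methoxycyclohexyl in place of 2-(oxan-4-yl)ethyl on an amide-type nitrogen in a ring. For the measured compounds named here, no measured pair shows this change, so only a small step in this assay is expected, upward if anything and within the scatter. The estimated step is a 1.4-fold higher number from compound 2 to compound 4 (0.16 log units; within the scatter). For compound 4 the expected clearance is 13 mL/min/kg, within an estimated range of 6 mL/min/kg to 30 mL/min/kg.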

Compound 4, clearance: 4.9 mL/min/kg
Compound 4: the middle estimate sits 2.7-fold (0.42 log units) above what was measured, and the stated range ends above it.
By their numbers in this assay, from the lowest: compounds 4 and 2 (each within the scatter of the next); then compound 1.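

Swapping the groups on the amide-type nitrogen gives a 1.8-fold lower number from compound 2 to compound 4 (0.26 log units; within the scatter) in this assay and so shows that, at this position, 4-methoxycyclohexyl with its carbon-only ring can stand in place of 2-(oxan-4-yl)ethyl with its oxygen-containing ring while the clearance stays within the usual scatter. No measurement shown gives a reason for this result. Compound 3 has the same atoms as compound 4 but a different stereo arrangement and carries no number, so the role of that arrangement cannot be read. As far as these compounds go, how an amine or a carboxylic acid on this ring would fare also stays open.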